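Pyrazine hydrazones: from bromo to ethoxy on the aryl ring

The source may hold more compounds than are shown below. What is called first, only, known or untested is meant among the compounds shown, and "the series" means these compounds.

Measured compounds:
Compound 1, `O=C(N/N=C/c1ccc(Cl)cc1)c1cnccn1`, gives 64%.
Compound 2, `O=C(N/N=C/c1ccc(F)cc1)c1cnccn1`, gives 69%.
Compound 3, `O=C(N/N=C/c1ccc(Br)cc1)c1cnccn1`, gives 100%.

All three share one core and differ only in the group on the aryl ring, and all were tested in an ADME assay on J774 cells (Mus musculus) for cytotoxicity, read by MTT assay, with a stated time of 48 h, tested at 100 ug/mL; a lower number here means a stronger effect, a higher number a weaker effect of the compound at the concentration tested. Compound 3 stands highest of the three numbers: the step of a number 36 percentage points higher from compound 1 to compound 3 (beyond the scatter) and the step of a number 31 percentage points higher from compound 2 to compound 3 (beyond the scatter) are both beyond the scatter, whereas the step of a number 5 percentage points higher from compound 1 to compound 2 (within the scatter) is within it. So the bromo compound shows the weakest effect, and the chloro and fluoro compounds cannot be told apart.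

Compound 4, `CCOc1ccc(/C=N/NC(=O)c2cnccn2)cc1`, has not been measured. It differs from compound 3 in one place: ethoxy in place of bromo on an aromatic carbon. The measured steps all swap one halogen for another; none brings in an ethoxy or any group with an oxygen, so they bear on this change only loosely. On these data alone, they show that the bromo compound sits apart from the two smaller halogens, which suggests that leaving bromo may move the number down, though how far is unknown. A downward step a number 20 percentage points lower from compound 3 to compound 4 (beyond the scatter) is therefore expected, with wide uncertainty. The estimate for compound 4 in this assay is 80%, in the range 55% to 105%.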

Compound 4, a percentage reported as activity, at one concentration (the size of the read-out at that concentration, not a potency): 98%
The estimate for compound 4 lay 18 percentage points below the measured number; the range from low to high includes it.
By their numbers in this assay, from the lowest: compounds 1 and 2 (each within the scatter of the next); then compounds 4 and 3 (each within the scatter of the next).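

In this assay the exchange of bromo for ethoxy, which puts three heavy atoms including one hydrogen-bond acceptor where a single bromine stood, gives a number 2 percentage points lower from compound 3 to compound 4 (within the scatter) and so leaves compound 3 and compound 4 impossible to tell apart. The high number is therefore not peculiar to bromo, since a group with no halogen at this same place on the aromatic ring also stands clear of the fluoro and chloro compounds, with a number 29 percentage points higher from compound 2 to compound 4 (beyond the scatter) and with a number 34 percentage points higher from compound 1 to compound 4 (beyond the scatter) in the same direction. Nothing shown here explains why bromo and ethoxy fall together while chloro and fluoro fall apart from them.

The compounds shown leave open whether methoxy, a longer chain such as butoxy, or an amine at this place would give a number like those of compound 3 and compound 4 or one like those of compound 1 and compound 2. They also vary only this one place, so they say nothing about how bromo or ethoxy would behave elsewhere on the ring or on a different core.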